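A few compounds are considered here, and "the series" means these few. Any claim that something is new, unique, unknown or untested is made for them only; others in the source may bear on it.

Measured compounds:
compound 1 `O=C1C(=O)N(CCCCn2cc(COc3cc(=O)oc4ccccc34)nn2)c2ccc(F)cc21` gives 77%
compound 2 `COc1ccc2c(c1)C(=O)C(=O)N2CCCCCn1cc(COc2cc(=O)oc3ccccc23)nn1` gives 30%
compound 3 `O=C1C(=O)N(CCCCCn2cc(COc3cc(=O)oc4ccccc34)nn2)c2ccc(Br)cc21` gives 52%

These three compounds were tested in a functional assay on THP-1 cells (Homo sapiens) for inhibition, read by sulforhodamine B assay, with a stated time of 48 h, tested at 50 uM; a higher number here means more inhibition of growth at the concentration tested, a lower number less inhibition of growth. Compound 3 stands second highest of the three numbers: compound 2 lies nearest to it, with a number 22 percentage points higher from compound 2 to compound 3 (beyond the scatter) separating the pair, while compound 1, which differs from compound 3 in more than one place, is furthest and has the highest number shown.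

Compound 4 `O=C1C(=O)N(CCCCCn2cc(COc3cc(=O)oc4ccccc34)nn2)c2ccccc21` has not yet been measured. It differs from compound 3 in one place: hydrogen in place of bromo on an aromatic carbon. Among the compounds with values here, the only measured step that touches the same aromatic carbon is the one from compound 2 to compound 3, where bromo in place of methoxy gave a number 22 percentage points higher from compound 2 to compound 3 (beyond the scatter), a change described as modest but beyond the scatter. Within the data shown here, no measured pair shows what removing the group altogether does. From this single step the expectation is that taking the bromo away will move the number in this assay downward by a small amount, possibly not beyond the scatter; the estimated step is a number 8 percentage points lower from compound 3 to compound 4 (within the scatter). Compound 4 is therefore expected to give about 44% in this assay, within a range from 24% to 64%.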

Compound 4, percent growth inhibition at one concentration: 69%
For compound 4 the middle estimate is 25 percentage points below the measured one; the measured number lies above the stated range.
By their numbers in this assay, from the lowest: compound 2; then compound 3; then compounds 4 and 1 (each within the scatter of the next).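

In this assay this aromatic carbon, meta to a fused ring and para to a fused ring, can now be read with no substituent at all: hydrogen in place of bromo gives a number 17 percentage points higher from compound 3 to compound 4 (beyond the scatter) and hydrogen in place of methoxy gives a number 39 percentage points higher from compound 2 to compound 4 (beyond the scatter) on the same shared core. The earlier step only ranked bromo against methoxy, whereas these two steps show that, of the three compounds with this chain, both compounds carrying a substituent at this place give less inhibition of growth than the compound with hydrogen there, with methoxy the further of the two from it. The data offered here give no measured property that would account for this order.

From the compounds shown here alone, compound 1 carries fluoro but also differs in its chain, so what fluoro does on this carbon with the chain of compound 4 stays open, and its number cannot be set against theirs. Going by these compounds, it also remains open whether a small group such as methyl, or an amine or a carboxylic acid at this carbon, would fall below the hydrogen compound as bromo and methoxy do.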